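A few compounds are considered here, and "the series" means these few. Any claim that something is new, unique, unknown or untested is made for them only; others in the source may bear on it.

In a functional assay on HUVEC cells (Homo sapiens) for antiproliferative activity, read by MTT assay, with a stated time of 24 h (on this read-out lower numbers stand for stronger inhibition and higher numbers for weaker inhibition), compound 1 (`COc1cc(OC)c(-c2coc3cc(OCC=C(C)C)ccc3c2=O)cc1OC`) gives 3800 nM. Compound 2 (`C=CCOc1ccc2c(=O)c(-c3cc(OC)c(OC)cc3OC)coc2c1`) gives > 10000 nM, which is a limit. Compound 3 (`COc1cc(OC)c(-c2coc3cc(OCc4ccccc4C(F)(F)F)ccc3c2=O)cc1OC`) gives > 10000 nM, also only a limit, so it has no number of its own. Within the data shown here, the series so far shows (the limit of > 10000 nM in this assay, at which 2 of the 3 values shown sit). Compound 4 (`COc1cc(OC)c(-c2coc3cc(OCc4ccccc4Cl)ccc3c2=O)cc1OC`) has chloro in place of trifluoromethyl on an aromatic carbon. The nearest measured changes are an at least 2.6-fold higher number from compound 1 to compound 2 (0.42 log units; beyond the scatter) and an at least 2.6-fold higher number from compound 1 to compound 3 (0.42 log units; beyond the scatter), both at least modest, yet neither tests this swap, and a step that the two limits leave unreadable from compound 2 to compound 3 gives no size. The expected step is a step that the limit leaves unreadable from compound 3 to compound 4, with none expected beyond the scatter. For compound 4 the estimated value is 12000 nM, within an expected range of 4000 nM to 30000 nM.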

Compound 4, half-maximal inhibitory concentration: > 10000 nM
Compound 4: only a limit was reported (the forecaster's own chance of this, stated with the estimate: 65%); the middle value does not contradict the limit.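

In this assay compound 4 gives > 10000 nM, which is a limit and not a number, so chloro in place of trifluoromethyl on this aromatic carbon yields no reading, and neither step into compound 4 from compound 2 or compound 3 can be read. Among these compounds, only one step is readable, with 2-chlorophenyl in place of 2-methylprop-1-en-1-yl: an at least 2.6-fold higher number from compound 1 to compound 4 (0.42 log units; beyond the scatter). Compound 1 remains the only compound with a measured number, as the series now gathers at one value: the limit of > 10000 nM in this assay, at which 3 of the 4 values shown sit.

Whether chloro and trifluoromethyl differ at all stays hidden behind the limit. As far as these compounds go, how a nitrile on that aromatic carbon, or a longer chain in place of 2-methylprop-1-en-1-yl, would read stays open.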